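Carbamate in place of ethyl on the amide ring

The source may hold more compounds than are shown below. What is called first, only, known or untested is meant among the compounds shown, and "the series" means these compounds.

Compound 2 `CCC1CCCN(C(=O)CN2CN(c3ccccc3)C3(CCN(C(=O)c4ccc(C5CCCCC5)cc4)CC3)C2=O)C1` gives 2600 nM in an assay on HEK293 cells for displacement of a labelled ligand from NPC1-like intracellular cholesterol transporter 1 (Homo sapiens) (a lower number here means a stronger inhibitor, a higher number a weaker inhibitor), the second highest of three numbers; the steps of a 1.3-fold lower number from compound 2 to compound 3 (0.11 log units; within the scatter) and a 2.3-fold lower number from compound 1 to compound 2 (0.36 log units; beyond the scatter) place it. Compound 1 `CC(C)(C)OC(=O)NCCCNC(=O)CN1CN(c2ccccc2)C2(CCN(C(=O)c3ccc(C4CCCCC4)cc3)CC2)C1=O` gives 6000 nM and compound 3 `O=C(CN1CN(c2ccccc2)C2(CCN(C(=O)c3ccc(C4CCCCC4)cc3)CC2)C1=O)NCCO` gives 2000 nM. Compound 4 `CC(C)(C)OC(=O)NC1CCCN(C(=O)CN2CN(c3ccccc3)C3(CCN(C(=O)c4ccc(C5CCCCC5)cc4)CC3)C2=O)C1` differs from compound 2 by (tert-butoxycarbonyl)amino in place of ethyl on a saturated ring carbon. Among the compounds with values here, two measured steps bear on this: the removal of a (tert-butoxycarbonyl)amino-bearing chain gave a 3.0-fold lower number from compound 1 to compound 3 (0.48 log units; beyond the scatter), and its replacement gave the modest step already noted. Compound 4 reintroduces that group, so a modest rise in number is expected, because a 3.0-fold lower number from compound 1 to compound 3 (0.48 log units; beyond the scatter) ran the other way. Compound 4 is estimated at 5000 nM, range 2000 nM to 15000 nM, an expected step of a 1.9-fold higher number from compound 2 to compound 4 (0.28 log units; within the scatter).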

Compound 4, half-maximal inhibitory concentration: 4400 nM
Estimate against measurement, compound 4: 1.1-fold (0.06 log units) above; the range from low to high includes it.
By their numbers in this assay, from the lowest: compounds 3, 2, 4 and 1 (each within the scatter of the next, the first and the last beyond it).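

On the saturated ring carbon two ring bonds from the ring nitrogen, the step in this assay is a 1.7-fold higher number from compound 2 to compound 4 (0.23 log units; within the scatter), so ethyl and (tert-butoxycarbonyl)amino are not separated here. The earlier compounds shown here carried this carbamate only on an open chain; here it sits on the ring, and 8 heavy atoms in place of 2 leave the number within the scatter. No measurement available here offers a cause for this result.

Still open, on these data alone, is whether a free amine or a carboxylic acid on this ring carbon would separate from ethyl. A longer chain at the same place is equally unresolved.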